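The source may hold more compounds than are shown below. What is called first, only, known or untested is meant among the compounds shown, and "the series" means these compounds.

Compound 1, `Cn1c(-c2ccccc2)cs/c1=N/C(=O)c1ccc(Cl)cc1`: 40%
Compound 2, `CCCCCCCCCCCC(=O)Nc1nc(-c2ccccc2)cs1`: 40%
Compound 3, `CCn1c(-c2ccccc2)cs/c1=N/C(=O)c1cccs1`: 40%

Of the compounds shown here, three have been measured in a functional assay on MDA-MB-231 cells (Homo sapiens) for inhibition, with a stated time of 24 h, tested at 10 uM; on this read-out lower numbers stand for less inhibition and higher numbers for more inhibition at the one concentration tested (going by the name of the read-out). Compound 1 gives 40%, compound 2 gives 40% and compound 3 gives 40%. Compound 1 therefore stands level with compounds 2 and 3 at the digits shown; the nearest is compound 2 and the furthest compound 3, and neither gap goes beyond the scatter of repeated measurements.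

Compound 4, `Cn1c(-c2ccccc2)cs/c1=N/C(=O)c1ccccc1`, has not yet been measured in this assay. It differs from compound 1 by hydrogen in place of chloro on an aromatic carbon. Among the compounds with values here, no pair of measured compounds differing in a single place is available, so the set itself gives no step that shows how this change acts. Since the three measured compounds sit together, the step from compound 1 to compound 4 is expected to be small, a number 5 percentage points lower from compound 1 to compound 4 (within the scatter), with no clear direction beyond the scatter. Compound 4 is accordingly estimated at 35%, between 20% and 50%.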

Compound 4, a percentage reported as inhibition, at one concentration (the size of the read-out at that concentration, not a potency): 40%
The estimate for compound 4 lay 5 percentage points below the measured number; the range from low to high includes it.
By their numbers in this assay, from the lowest: compounds 1, 2, 3 and 4 (each within the scatter of the next).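

In this assay, within the data shown here, the change from 4-chlorophenyl to phenyl gives no change at the digits printed from compound 1 to compound 4 (within the scatter) and is the first single-place comparison in this set. Chloro on this aromatic carbon, para to a large group, can thus be replaced by hydrogen without a change in the read-out beyond the scatter. No available evidence accounts for this result.

What the compounds shown leave open is whether a larger or different group at this place, such as an amine, a carboxylic acid or a longer chain, would move the number. They also leave open whether chloro and hydrogen would remain level at other concentrations.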